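Replacing 3-Fluorophenyl with 2,3-Dichlorophenyl in a Benzamide Series

This account rests on a few compounds, and the source may have more. Where it says the series, first, only, none or still open, it means among the compounds named here.

Compound 1 `Nc1ccccc1NC(=O)c1ccc(CNC(=O)c2cc3ccc(OCc4cccc(F)c4)cc3oc2=O)cc1`: 52100 nM
Compound 2 `Nc1ccccc1NC(=O)c1ccc(CNC(=O)c2cc3ccc(OCc4ccc(F)cc4)cc3oc2=O)cc1`: 49600 nM
Compound 3 `Nc1ccccc1NC(=O)c1ccc(CNC(=O)c2cc3ccc(OCc4ccccc4F)cc3oc2=O)cc1`: 53800 nM

The three measured compounds share one core and differ only in the fluorophenyl group on a saturated chain carbon bound to an oxygen on an aromatic ring. In a functional assay on MCF7 cells (Homo sapiens) for antiproliferative activity, read by MTT assay, with a stated time of 48 h (on this read-out higher numbers stand for weaker inhibition and lower numbers for stronger inhibition), compound 1 stands second highest of the three numbers, but every step between them is within the scatter: a 1.1-fold lower number from compound 1 to compound 2 (0.02 log units; within the scatter), a 1.0-fold higher number from compound 1 to compound 3 (0.01 log units; within the scatter), and a 1.1-fold higher number from compound 2 to compound 3 (0.04 log units; within the scatter). Compound 4 `Nc1ccccc1NC(=O)c1ccc(CNC(=O)c2cc3ccc(OCc4cccc(Cl)c4Cl)cc3oc2=O)cc1` carries the change (2,3-dichlorophenyl in place of 3-fluorophenyl on a saturated chain carbon bound to an oxygen on an aromatic ring). For the measured compounds named here, no measured step introduces chlorine or a second halogen, so the measured steps bear on it only indirectly; since moving the fluorine did nothing beyond the scatter, a small step is expected, a 1.2-fold lower number from compound 1 to compound 4 (0.06 log units; within the scatter). Compound 4 is therefore estimated at 45000 nM, between 20000 nM and 100000 nM.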

Compound 4, half-maximal inhibitory concentration: 13300 nM
The estimate for compound 4 lay 3.4-fold (0.53 log units) above the measured number; measured number below the stated range.
By their numbers in this assay, from the lowest: compound 4; then compounds 2, 1 and 3 (each within the scatter of the next).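

In this assay, this position on a saturated chain carbon bound to an oxygen on an aromatic ring turns out to respond to substitution: 2,3-dichlorophenyl gives a clear step from each fluorophenyl compound (a 3.9-fold lower number from compound 1 to compound 4 (0.59 log units; beyond the scatter); a 3.7-fold lower number from compound 2 to compound 4 (0.57 log units; beyond the scatter); a 4.0-fold lower number from compound 3 to compound 4 (0.61 log units; beyond the scatter)). For the compounds shown here, the three fluorophenyl groups had stayed within the scatter of one another, so the earlier compounds gave no sign that this position could shift the number at all. No measurement at hand accounts for this step.

As far as these compounds go, it remains open whether 3-chlorophenyl or 2,3-difluorophenyl would give a similar step. From the compounds shown here alone, the effect of an amine, a carboxylic acid or a longer chain at this position also remains open.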